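A few compounds are considered here, and "the series" means these few. Any claim that something is new, unique, unknown or untested is made for them only; others in the source may bear on it.

Measured compounds:
Compound 1 `Cc1ccc(Nc2nc(N)nc(COc3ccc4c(C)cc(=O)oc4c3)n2)cc1`: in an assay on COS-7 cells for agonist activity at Free fatty acid receptor 1 (Homo sapiens), read by scintillation counting and inositol phosphate accumulation, with a stated time of 90 min (on this read-out lower numbers stand for an effect already at smaller amounts and higher numbers for an effect only at larger amounts of compound), compound 1 gives 1790 nM.
Compound 2 `Cc1cc(=O)oc2cc(OCc3nc(N)nc(Nc4cccc(Cl)c4)n3)ccc12`: in this assay compound 2 gives 1110 nM.

Among the measured compounds shown here, compound 2 holds the lowest of the two numbers measured so far, but its only neighbour is close: the step of a 1.6-fold lower number from compound 1 to compound 2 (0.21 log units; within the scatter) stays within the scatter, so the two compounds are not distinguished by these data.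

The next compound, compound 3 `Cc1cc(=O)oc2cc(OCc3nc(N)nc(Nc4ccc(C5CC5)cc4)n3)ccc12`, differs from compound 2 in one place: 4-cyclopropylphenyl in place of 3-chlorophenyl on a nitrogen on an aromatic ring.

For the measured compounds named here, only one measured step bears on this change, since it also exchanges the group on the same nitrogen of the shared core: a 1.6-fold lower number from compound 1 to compound 2 (0.21 log units; within the scatter), a step within the scatter. Going by the values given here, no measured compound carries 4-cyclopropylphenyl at this position, so nothing speaks for a shift in either direction. The expectation is therefore a step of no more than the scatter, estimated as a 1.1-fold lower number from compound 2 to compound 3 (0.05 log units; within the scatter).

For compound 3 the estimate in this assay is 1000 nM, with a range from 400 nM to 2500 nM.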

Compound 3, half-maximal effective concentration: 700 nM
Compound 3: the middle estimate sits 1.4-fold (0.15 log units) above what was measured, within the range that was stated.
By their numbers in this assay, from the lowest: compounds 3, 2 and 1 (each within the scatter of the next, the first and the last beyond it).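

In this assay, cyclopropyl in place of methyl on an aromatic carbon gives a 2.6-fold lower number from compound 1 to compound 3 (0.41 log units; beyond the scatter), a modest step and the first in the series to lie beyond the scatter, so a change in this group on the nitrogen can register on this read-out. Exchanging 3-chlorophenyl for 4-cyclopropylphenyl gives a 1.6-fold lower number from compound 2 to compound 3 (0.20 log units; within the scatter), which leaves compound 2 and compound 3 undistinguished, so these two quite different aryl groups cannot be separated by these data, although one carries chlorine and the other an added three-membered ring. The series holds no measurement that could explain either step.

Compound 2 and compound 3 differ in both the substituent and its place on the phenyl ring, so 4-chlorophenyl and 3-cyclopropylphenyl would be needed to separate those two contributions. On these data alone, it also remains open whether the modest step seen with cyclopropyl extends to larger carbon groups such as cyclobutyl or tert-butyl, or holds up with an amine or a carboxylic acid on the same phenyl ring.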